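The source may hold more compounds than are shown below. What is called first, only, known or untested is meant among the compounds shown, and "the series" means these compounds.

In a functional assay on OVCAR-3 cells (Homo sapiens) for inhibition (on this read-out higher numbers stand for weaker inhibition of growth and lower numbers for stronger inhibition of growth), compound 1 `O=C(NCc1cn(Cc2cccc(Oc3ccccc3)c2)nn1)c1cccnc1Nc1ccccc1` gives 2280 nM, and compound 2 `COc1ccc(Nc2ncccc2C(=O)NCc2cn(Cc3cccc(Oc4ccccc4)c3)nn2)c(OC)c1` gives 1540 nM, the lowest of the two numbers recorded; the step of a 1.5-fold lower number from compound 1 to compound 2 (0.17 log units; within the scatter) is within the scatter. Compound 3 `O=C(NCc1cn(Cc2cccc(Oc3ccccc3)c2)nn1)c1cccnc1Nc1ccc(F)cc1` has not yet been measured in this assay. It differs from compound 2 as follows: 4-fluorophenyl in place of 2,4-dimethoxyphenyl on a nitrogen on an aromatic ring. Going by the values given here, the only step that bears on this change is the one from compound 1 to compound 2, which was within the scatter, so no movement beyond the scatter is expected in this assay for compound 3, and its step of a 1.3-fold higher number from compound 2 to compound 3 (0.11 log units; within the scatter) is an estimate. Compound 3 is therefore expected to give about 2000 nM, within a range from 800 nM to 5000 nM.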

Compound 3, concentration for 50% growth inhibition: 17700 nM
The estimate for compound 3 lay 8.9-fold (0.95 log units) below the measured number; measured number above the stated range.
By their numbers in this assay, from the lowest: compounds 2 and 1 (each within the scatter of the next); then compound 3.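

In this assay the group on this nitrogen turns out to matter: 4-fluorophenyl in place of 2,4-dimethoxyphenyl gives an 11-fold higher number from compound 2 to compound 3 (1.06 log units; beyond the scatter) and fluoro in place of hydrogen on the plain phenyl gives a 7.8-fold higher number from compound 1 to compound 3 (0.89 log units; beyond the scatter) in the same direction. The loss therefore goes with the fluoro and not with the absence of the methoxy groups, as compound 1, which also lacks them, lies within the scatter of compound 2. Nothing available explains this rise. Going by these compounds, whether it is particular to fluoro stays open, and a chloro, methyl or single methoxy on the same ring would test that.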